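Iodo to methyl on a small growth-inhibition series

The source may report more compounds than this note shows. Statements on the series, on what has been measured and on what is new or still open speak of the compounds shown alone.

- compound 1 `c1cc(OC2CCCC2)ccc1NC1=NCCO1`: 23100 nM
- compound 2 `Ic1ccc(NC2=NCCO2)cc1`: 2900 nM

In a functional assay on MCF7 cells (Homo sapiens) for inhibition, read by sulforhodamine B assay, with a stated time of 48 h (a higher number here means a weaker inhibitor of growth, a lower number a stronger inhibitor of growth), compound 2 holds the lower of the two numbers, at 2900 nM. The next structure, compound 3 `Cc1ccc(NC2=NCCO2)cc1`, has methyl in place of iodo on an aromatic carbon. Going by the values given here, only one measured step bears on this change: an 8.0-fold lower number from compound 1 to compound 2 (0.90 log units; beyond the scatter), a modest step beyond the scatter that came with iodo in place of cyclopentyloxy. Among the compounds with values here, no measured compound carries methyl, so that step gives only a rough scale. Losing the iodo of compound 2, at 2900 nM, is expected to raise the number by a modest amount, though a change within the scatter remains possible. The expected shift is a 2.8-fold higher number from compound 2 to compound 3 (0.44 log units; beyond the scatter). For compound 3, the estimated value is 8000 nM, with an expected range of 2500 nM to 25000 nM.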

Compound 3, concentration for 50% growth inhibition: 27000 nM
Estimate against measurement, compound 3: 3.4-fold (0.53 log units) below; measured number above the stated range.
By their numbers in this assay, from the lowest: compound 2; then compounds 1 and 3 (each within the scatter of the next).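

Working notes: in this assay methyl in place of iodo gives a 9.3-fold higher number from compound 2 to compound 3 (0.97 log units; beyond the scatter) for a swap of one heavy atom for one heavy atom, with no ring, hydrogen-bond donor, hydrogen-bond acceptor or net charge entering or leaving, so a single-atom change at this aromatic carbon is enough to move the number beyond the scatter. Methyl in place of cyclopentyloxy gives a 1.2-fold higher number from compound 1 to compound 3 (0.07 log units; within the scatter) and stays within the scatter, so among the three groups at this position only iodo sets a compound apart. Nothing measured here accounts for the iodo result.

Open, on these data alone, is whether bromo or chloro at this position would track iodo or methyl. Also open, as far as these compounds go, is whether an ethyl chain or an amine there would stay level with methyl and cyclopentyloxy.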